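Compound 3: 3,4,5-trimethoxyphenyl in place of 2-(hydroxymethyl)phenyl

This account rests on a few compounds, and the source may have more. Where it says the series, first, only, none or still open, it means among the compounds named here.

Measured in a functional assay on MCF7 cells (Homo sapiens) for inhibition, read by sulforhodamine B assay, with a stated time of 48 h, tested at 50 uM; a higher number here means more inhibition of growth at the concentration tested, a lower number less inhibition of growth:
- compound 1 `COc1ccc([C@@H]2C/C(=N/OCc3cn(-c4ccc(O)cc4)nn3)c3cc(CC=C(C)C)c(OC)cc3O2)cc1`: 63%
- compound 2 `COc1ccc([C@@H]2C/C(=N/OCc3cn(-c4ccccc4CO)nn3)c3cc(CC=C(C)C)c(OC)cc3O2)cc1`: 100%

Compound 2 stands highest of the two at 100%, with compound 1 beyond the scatter below it. Compound 3 `COc1ccc([C@@H]2C/C(=N/OCc3cn(-c4cc(OC)c(OC)c(OC)c4)nn3)c3cc(CC=C(C)C)c(OC)cc3O2)cc1` carries 3,4,5-trimethoxyphenyl in place of 2-(hydroxymethyl)phenyl on an aromatic nitrogen of a five-membered aromatic ring with 3 nitrogen: 3,4,5-trimethoxyphenyl in place of 2-(hydroxymethyl)phenyl on an aromatic nitrogen. Within the data shown here, one measured step bears on this change: a number 37 percentage points higher from compound 1 to compound 2 (beyond the scatter). That large step swapped a group at the same place, 2-(hydroxymethyl)phenyl in place of 4-hydroxyphenyl. Among the measured compounds shown here, a single step is thin evidence, and no compound with 3,4,5-trimethoxyphenyl has a value yet. Since compound 2 sits at 100%, a fall in this assay is expected, of moderate to large size and beyond the scatter. The expected change is a number 30 percentage points lower from compound 2 to compound 3 (beyond the scatter). For compound 3 the estimated value is 70%, with an expected range of 45% to 95%.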

Compound 3, percent growth inhibition at one concentration: 45%
For compound 3 the middle estimate is 25 percentage points above the measured one; the measured number falls inside the stated range.
By their numbers in this assay, from the lowest: compound 3; then compound 1; then compound 2.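

In this assay, the aromatic nitrogen now carries three groups whose readings all lie apart beyond the scatter, so the position tolerates no free exchange of aryl groups: the change gives a number 55 percentage points lower from compound 2 to compound 3 (beyond the scatter), and against the phenol it gives a number 18 percentage points lower from compound 1 to compound 3 (beyond the scatter). 3,4,5-Trimethoxyphenyl is thus the lowest of the three, and the exchange from 2-(hydroxymethyl)phenyl removes a hydrogen-bond donor while also adding heavy atoms and hydrogen-bond acceptors, so the data cannot separate these changes. Nothing measured on these compounds explains the fall.

The compounds shown leave open how 2-(aminomethyl)phenyl or a phenyl carrying a carboxylic acid would read at this position. Also open, as far as these compounds go, is whether one methoxy group alone on the phenyl ring would give a similar fall.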